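The source may hold more compounds than are shown below. What is called first, only, known or untested is meant among the compounds shown, and "the series" means these compounds.

Working notes on the series. Among the compounds with values here, in an ADME assay on HEK293-A cells (Homo sapiens) for cytotoxicity, read by MTT assay, with a stated time of 48 h (a lower number here means a stronger inhibitor, a higher number a weaker inhibitor), compound 1 (`CN1CCN(C[C@H]2CN(c3ccc(-n4cc(-c5ccccn5)cn4)c(F)c3)C(=O)O2)CC1`) gives 70 ug/mL and stands lowest of the two numbers so far, with compound 2 (`COC(=O)CC1CCN(C[C@H]2CN(c3ccc(-n4cc(-c5ccccn5)cn4)c(F)c3)C(=O)O2)CC1`) at 224 ug/mL as its nearest neighbour. The next change leads to compound 3 (`O=C1CNC(=O)N1C[C@H]1CN(c2ccc(-n3cc(-c4ccccn4)cn3)c(F)c2)C(=O)O1`) and falls on a saturated chain carbon bound to a saturated ring carbon, leaving the shared core untouched: 2,5-dioxoimidazolidin-1-yl in place of 4-methylpiperazin-1-yl on a saturated chain carbon bound to a saturated ring carbon is the whole difference. Within the data shown here, only one measured step bears on it. Compound 2 also gives up 4-methylpiperazin-1-yl at this place, taking 4-((methoxycarbonyl)methyl)piperidin-1-yl instead, and the result is modest but beyond the scatter (a 3.2-fold higher number from compound 1 to compound 2 (0.51 log units; beyond the scatter)). Among the measured compounds shown here, the entering group there is not the one in compound 3, and no measured compound carries 2,5-dioxoimidazolidin-1-yl, so this precedent gives a direction and only a loose size. An upward step somewhat smaller than that one is expected (a 2.1-fold higher number from compound 1 to compound 3 (0.33 log units; beyond the scatter)). For compound 3 the estimated value is 150 ug/mL (expected range 60 ug/mL to 400 ug/mL).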

Compound 3, half-maximal inhibitory concentration: > 400 ug/mL
Compound 3 was reported as a limit; the forecaster's own chance of this, stated with the estimate: 15%; middle value at least 2.6-fold (0.42 log units) from the limit.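

At this place, on a saturated chain carbon bound to a saturated ring carbon, a second and quite different entering group also moves the number up in this assay: 2,5-dioxoimidazolidin-1-yl for 4-methylpiperazin-1-yl gives an at least 5.7-fold higher number from compound 1 to compound 3 (0.75 log units; beyond the scatter). Both replacements of 4-methylpiperazin-1-yl shown now point the same way, since the earlier change gave a 3.2-fold higher number from compound 1 to compound 2 (0.51 log units; beyond the scatter). Compound 3 is reported only as a limit and not as a number, so the full size of its steps stays unread, and the floor of an at least 1.7-fold higher number from compound 2 to compound 3 (0.25 log units; that floor lies within the scatter) does not order the two entering groups: the limit of > 400 ug/mL in this assay, at which 1 of the 3 values shown sits.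

The compounds shown leave open whether the upward direction holds for a plain piperidin-1-yl, a morpholin-4-yl or an open-chain dimethylamino group at this place, as each entering group shown changes the ring and what it carries together. Also open, from the compounds shown here alone, is whether the number follows the carbonyl groups of 2,5-dioxoimidazolidin-1-yl or its five-membered ring, and whether any group here gives a number lower than compound 1 gives at 70 ug/mL.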